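Methylating the Naphthol Oxygen: An Expectation for Compound 4

This account rests on a few compounds, and the source may have more. Where it says the series, first, only, none or still open, it means among the compounds named here.

Compound 1, `N#CC1=C(N)N(c2ccc(S(N)(=O)=O)cc2)C2=C(CCCC2)C1c1ccccc1`, in a functional assay on Ehrlich cells (Mus musculus) for cytotoxicity, read by trypan blue exclusion, with a stated time of 2 h (on this read-out higher numbers stand for weaker inhibition and lower numbers for stronger inhibition), gives only a limit of the assay, > 100 ug/mL.
Compound 2, `N#CC1=C(N)N(c2ccc(S(N)(=O)=O)cc2)C2=C(CCCC2)C1c1cccc([N+](=O)[O-])c1`, in this assay also gives only a limit, > 100 ug/mL.
Compound 3, `N#CC1=C(N)N(c2ccc(S(N)(=O)=O)cc2)C2=C(CCCC2)C1c1c(O)ccc2ccccc12`, in this assay gives 100 ug/mL.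

Compound 3 is thus the only one of the three with an actual number; the other two sit at the limit of > 100 ug/mL in this assay, at which 2 of the 3 values shown sit. Compound 4, `COc1ccc2ccccc2c1C1C(C#N)=C(N)N(c2ccc(S(N)(=O)=O)cc2)C2=C1CCCC2`, differs from compound 3 by methyl in place of hydrogen on an oxygen on an aromatic ring.

Among the compounds with values here, no measured step changes this oxygen, so none bears on it directly. The steps that touch the same ring substituent, a number no higher from compound 1 to compound 3 (the limit leaves the size open) and a number no higher from compound 2 to compound 3 (the limit leaves the size open), are of unreadable size; a step that the two limits leave unreadable from compound 1 to compound 2 is likewise unreadable. Within the data shown here, all three show only that nothing so far has moved clearly away from the limit, and nothing among them points to a change beyond the scatter for so small an alteration.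

Compound 4 is therefore expected to give about 100 ug/mL in this assay, between 50 ug/mL and 200 ug/mL, and the expected step of no change at the digits printed from compound 3 to compound 4 (within the scatter) is no change beyond the scatter.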

Compound 4, half-maximal inhibitory concentration: 100 ug/mL
Compound 4: middle estimate and measured number agree at the digits printed; measured number inside the range.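

Turning hydroxy into methoxy on this oxygen brings no change at the digits printed from compound 3 to compound 4 (within the scatter) in this assay. This is the first step among the compounds shown with a real number at both ends, so it is the first whose size can be read, whereas the earlier steps cannot be read. Within the data shown here, it also bears directly on the oxygen, which no earlier step touched: with methyl in place of the hydrogen on that oxygen, compound 4 gives 100 ug/mL, so in this assay that hydrogen can be replaced by methyl with no change beyond the scatter.

On these data alone, whether a longer chain such as ethyl or benzyl on this oxygen, or an amine or a carboxylic acid at this place, would shift the number remains open, since a single small methyl step says little about larger or different groups. How far compound 3 and compound 4 stand from compound 1 and compound 2 also cannot be told, because the values of those two compounds are limits and not numbers: the limit of > 100 ug/mL in this assay, at which 2 of the 4 values shown sit.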